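A methoxy-to-fluoro change awaiting its single measurement

The source may hold more compounds than are shown below. What is called first, only, known or untested is meant among the compounds shown, and "the series" means these compounds.

Compound 1 `COc1ccc(-c2nc3ccccc3s2)cc1NC(=O)c1cnccc1Cl`, compound 2 `O=C(Nc1cc(-c2nc3ccccc3s2)ccc1F)c1cnccc1Cl` and compound 3 `COc1ccc(-c2nc3ccccc3o2)cc1NC(=O)c1cnccc1Cl` were tested in an ADME assay on HepG2 cells (Homo sapiens) for inhibition, with a stated time of 72 h; on this read-out higher numbers stand for an effect only at larger amounts of compound and lower numbers for an effect already at smaller amounts. In this assay compound 1 gives only a limit, > 25000 nM. In this assay compound 2 likewise gives only a limit, > 25000 nM. In this assay compound 3 also gives only a limit, > 25000 nM. The change from compound 1 to compound 2 is fluoro in place of methoxy on an aromatic carbon, and its step is a step that the two limits leave unreadable from compound 1 to compound 2. The two cores differ by 1,3-benzoxazol-2-yl in place of 1,3-benzothiazol-2-yl on an aromatic carbon, and that step is a step that the two limits leave unreadable from compound 1 to compound 3. Every measured value sits at the limit of > 25000 nM in this assay, at which 3 of the 3 values shown sit. Compound 4 `O=C(Nc1cc(-c2nc3ccccc3o2)ccc1F)c1cnccc1Cl` is not yet measured; it differs from compound 3 by fluoro in place of methoxy on an aromatic carbon, the same kind of change as from compound 1 to compound 2, though here the place is para to a 1,3-benzoxazol-2-yl group rather than para to a 1,3-benzothiazol-2-yl group. Because every shown value sits at the limit of > 25000 nM in this assay, at which 3 of the 3 values shown sit, compound 4 is expected to give 40000 nM. The expected step is a step that the limit leaves unreadable from compound 3 to compound 4, most likely again only a limit.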

Compound 4, half-maximal effective concentration: > 25000 nM
Compound 4: a limit, no number; the forecaster's own chance of this, stated with the estimate: 80%; the middle value does not contradict the limit.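

No new step can be read between compound 3 and compound 4, since both give only a limit. The compounds shown leave open how any of these changes affects the read-out, as every value sits at one limit: the limit of > 25000 nM in this assay, at which 4 of the 4 values shown sit.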